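The source may report more compounds than this note shows. Statements on the series, on what has been measured and on what is new or still open speak of the compounds shown alone.

Measured in an ADME assay on MT4 cells (Homo sapiens) for cytotoxicity, read by MTT assay; a higher number here means that more compound is tolerated, a lower number that less compound is tolerated:
compound 1 `O=C(CSc1nncnc1-c1ccccc1Cl)c1ccc(Cl)c(Cl)c1`: 33000 nM
compound 2 `Cc1ccc(NC(=O)CSc2nncnc2-c2cccc3ccccc23)c(Br)c1`: 166000 nM
compound 3 `COC(=O)c1ccc(NC(=O)CSc2nncnc2-c2cccc3ccccc23)c(Br)c1`: 173000 nM

Compound 2 gives 166000 nM, and compound 3 gives 173000 nM. These two values lie within the scatter of each other, so they count as level. Compound 1 gives a lower number, 33000 nM, which is the furthest from compound 2 of the three.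

Compound 4 `O=C(CSc1nncnc1-c1cccc2ccccc12)Nc1ccccc1` has not been measured yet. It differs from compound 2 in one place: phenyl in place of 2-bromo-4-methylphenyl on an amide-type nitrogen. In words, this is phenyl in place of 2-bromo-4-methylphenyl on an amide-type nitrogen, so both the bromine and the methyl are gone.

Going by the values given here, only one measured step touches this group: a 1.0-fold higher number from compound 2 to compound 3 (0.02 log units; within the scatter). There, methoxycarbonyl took the place of methyl on an aromatic carbon, and the number stayed within the scatter. Among the compounds with values here, that is a single pair of compounds, and no measured pair shows what losing the bromine does.

In this assay, no step beyond the scatter is therefore expected, and the direction is open. The expected step is a 1.1-fold lower number from compound 2 to compound 4 (0.04 log units; within the scatter). The untested bromine keeps the range wide. For compound 4 the estimate is 150000 nM, with an expected range from 70000 nM to 300000 nM.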

Compound 4, half-maximal cytotoxic concentration: 154000 nM
Compound 4: middle estimate off by 1.0-fold (0.01 log units), on the low side, within the range that was stated.
By their numbers in this assay, from the lowest: compound 1; then compounds 4, 2 and 3 (each within the scatter of the next).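

In this assay the change to the group on the amide-type nitrogen gives a 1.1-fold lower number from compound 2 to compound 4 (0.03 log units; within the scatter) and this step stays within the scatter. The earlier pair of compound 2 and compound 3 altered only the methyl, whereas this step takes away the bromine and the methyl together, leaving plain phenyl with 6 heavy atoms in place of 2-bromo-4-methylphenyl with 8, so this position now has a second change that brings no step beyond the scatter. No measurement shown here offers a reason for this level result.

Because the two groups leave in a single step, the compounds shown cannot say what the bromine or the methyl does alone, and a level sum could hide two opposite contributions. Also open, going by these compounds, is how the number responds when the phenyl carries a carboxylic acid or an amine, or when a longer chain stands on the amide-type nitrogen in place of the phenyl.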